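Swapping a chloro for methoxy on the shared core

A few compounds are considered here, and "the series" means these few. Any claim that something is new, unique, unknown or untested is made for them only; others in the source may bear on it.

Measured so far:
- compound 1 `Nc1cc(-c2cnc3[nH]cc(-c4ccncc4)c3c2)ccc1Cl` — 12000 nM
- compound 2 `Nc1cncc(-c2cnc3[nH]cc(-c4ccncc4)c3c2)c1` — 5100 nM
- compound 3 `CNc1cccc(-c2cnc3[nH]cc(-c4ccncc4)c3c2)c1` — 4500 nM

In a functional assay on MCF7 cells (Homo sapiens) for cytotoxicity, read by MTT assay, with a stated time of 48 h (a lower number here means a stronger inhibitor, a higher number a weaker inhibitor), compound 1 gives the highest number of the three, so it is the weakest inhibitor shown; its nearest neighbour is compound 2, and compound 3 lies furthest off, both differences beyond the scatter. Compound 4 `COc1ccc(-c2cnc3[nH]cc(-c4ccncc4)c3c2)cc1N` keeps the core of compound 1 and changes one group: methoxy in place of chloro on an aromatic carbon. For the measured compounds named here, no pair of measured compounds separated by a single change is available, so the size of this step is not known from the data. The step from compound 1 to compound 4 is expected to be small, a 1.3-fold lower number from compound 1 to compound 4 (0.12 log units; within the scatter), perhaps within the scatter. Compound 4 is therefore estimated at 9000 nM, in the range 4000 nM to 20000 nM.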

Compound 4, half-maximal inhibitory concentration: 8700 nM
Compound 4: middle estimate off by 1.0-fold (0.01 log units), on the high side, and the stated range covers the measured number.
By their numbers in this assay, from the lowest: compounds 3, 2, 4 and 1 (each within the scatter of the next, the first and the last beyond it).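

For the compounds shown here, this is the first single change that can be read directly: in this assay, methoxy in place of chloro, ortho to an amino group, gives a small step (a 1.4-fold lower number from compound 1 to compound 4 (0.14 log units; within the scatter)) . At this position, the two groups cannot be told apart in this assay, even though methoxy brings a hydrogen-bond acceptor that chloro lacks. Nothing measured here explains this result.

Going by these compounds, whether a carboxylic acid or a longer chain such as butoxy on this carbon would shift the number beyond the scatter remains open.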